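Moving a Phenol Hydroxyl Group Around a Pyridine-Free Core

The source may hold more compounds than are shown below. What is called first, only, known or untested is meant among the compounds shown, and "the series" means these compounds.

Of the compounds shown here, three sharing one core have been tested so far. Compound 1 `Oc1cccc(-c2cc(-c3ccccc3O)nc(-c3ccccc3O)c2)c1` carries three 2-hydroxyphenyl groups, and in a functional assay on HCT-15 cells (Homo sapiens) for cytotoxicity, read by CCK-8 assay, with a stated time of 4 days (a higher number here means a weaker inhibitor, a lower number a stronger inhibitor), compound 1 gives 5020 nM. Compound 2 `Oc1ccc(-c2cc(-c3ccccc3O)cc(-c3ccccc3O)n2)cc1` gives 8240 nM in this assay, a value within the scatter of compound 1; the difference between the two cores is not broken down here.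

Among the compounds with values here, compound 3 `Oc1ccc(-c2cc(-c3cccc(O)c3)cc(-c3ccccc3O)n2)cc1` is the one measured compound in which a 2-hydroxyphenyl group has been replaced. For compound 3, this assay reports only a limit, > 50000 nM, rather than a number (the limit of > 50000 nM in this assay, at which 1 of the 3 values shown sits). The change from compound 1 to compound 3 is 4-hydroxyphenyl in place of 2-hydroxyphenyl on an aromatic carbon and it produced an at least 9.9-fold higher number from compound 1 to compound 3 (0.99 log units; beyond the scatter). Compound 3 also differs from compound 2, and that step is an at least 6.0-fold higher number from compound 2 to compound 3 (0.78 log units; beyond the scatter).

Compound 4 `Oc1ccc(-c2cc(-c3ccccc3O)cc(-c3ccc(O)cc3)n2)cc1` has not yet been measured. It arises from compound 2 by 4-hydroxyphenyl in place of 2-hydroxyphenyl on an aromatic carbon. The surroundings differ from the step to compound 3: there the site was meta to a 3-hydroxyphenyl group, here it is meta to a 4-hydroxyphenyl group, so this is the same kind of change rather than the same change.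

Resting on an at least 9.9-fold higher number from compound 1 to compound 3 (0.99 log units; beyond the scatter) from compound 1, the step from compound 2 to compound 4 is expected to be a 7.3-fold higher number from compound 2 to compound 4 (0.86 log units; beyond the scatter). Compound 4 is therefore estimated at 60000 nM in this assay, between 20000 nM and 200000 nM, quite possibly again reported only as a limit.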

Compound 4, half-maximal inhibitory concentration: 1920 nM
Beside the measured number, compound 4's estimate is 31-fold (1.49 log units) above it; the whole stated range lies above it.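

In this assay, putting a 4-hydroxyphenyl group where a 2-hydroxyphenyl group stood, on the carbon next to the ring nitrogen, gave a 4.3-fold lower number from compound 2 to compound 4 (0.63 log units; beyond the scatter), so here the change produced a stronger inhibitor rather than the weaker one seen earlier. In this series, the same kind of swap therefore did not carry over from one core to the other, and the two results point in opposite directions: the same change on two cores in this assay, an at least 9.9-fold higher number (0.99 log units; beyond the scatter) from compound 1 to compound 3 and a 4.3-fold lower number (0.63 log units; beyond the scatter) from compound 2 to compound 4, at least 42-fold (1.63 log units) apart, beyond the scatter of two such steps. These two steps show that knowing the result of this swap on one core did not predict its result on the other, but they do not show why the outcomes differ, and two steps cannot supply a rule for any further core in the series.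

The compounds shown carry only hydroxyphenyl groups, so it remains open whether the hydroxyl group itself is needed, which a methoxy group or an amine in its place, or a plain phenyl ring, would help to test. Also open, as far as these compounds go, is whether the opposite outcomes would recur if the same swap were made at other places on these cores.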